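This account rests on a few compounds, and the source may have more. Where it says the series, first, only, none or still open, it means among the compounds named here.

Compound 1 `CCCOCCNC1=Nc2ccccc2C(C)N1` and compound 2 `CCOCCCNC1=Nc2ccccc2C(C)N1` share one core and differ only in the side chain on the amine nitrogen. In an assay on isolated protein for binding affinity to 5-hydroxytryptamine receptor 5A (Homo sapiens) (on this read-out higher numbers stand for weaker inhibition and lower numbers for stronger inhibition), compound 1 gives 241 nM, and compound 2 gives 176 nM. Among the compounds with values here, the change a 1.4-fold lower number from compound 1 to compound 2 (0.14 log units; within the scatter) is small, so the two numbers cannot be told apart, and compound 2 stands within the usual scatter of the only other compound measured. Compound 3 `CC1NC(NC[C@H]2CCCO2)=Nc2ccccc21` is the next compound: oxolan-2-yl in place of 2-ethoxyethyl on a saturated chain carbon bound to an amine nitrogen. Within the data shown here, the only measured step that bears on this change is the swap of ether position from compound 1 to compound 2, and that step stayed within the scatter; no measured step closes a chain into a ring. On that basis the step of a 1.1-fold higher number from compound 2 to compound 3 (0.06 log units; within the scatter) is expected to be modest, with no clear direction. Compound 3 is therefore estimated at 200 nM in this assay, within a range from 60 nM to 700 nM.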

Compound 3, inhibition constant: 163 nM
For compound 3 the middle estimate is 1.2-fold (0.09 log units) above the measured one, within the range that was stated.
By their numbers in this assay, from the lowest: compounds 3, 2 and 1 (each within the scatter of the next).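

In this assay, replacing the open 2-ethoxyethyl chain with the oxolan-2-yl ring gives a small step (a 1.1-fold lower number from compound 2 to compound 3 (0.03 log units; within the scatter)), and replacing propoxymethyl with the same ring also gives a small step (a 1.5-fold lower number from compound 1 to compound 3 (0.17 log units; within the scatter)). This is the first view of a ring on a saturated chain carbon bound to an amine nitrogen, and among these three compounds an open chain and a five-membered ring of the same heavy-atom count cannot be told apart on this read-out. No supporting information bears on why these numbers sit so close together. The compounds shown leave open how the mirror-image form of the oxolan-2-yl ring would read here. They also leave open what a longer chain, an amine or a carboxylic acid would do at this place.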